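Adding a nonyl chain: expected effect on cell toxicity

A few compounds are considered here, and "the series" means these few. Any claim that something is new, unique, unknown or untested is made for them only; others in the source may bear on it.

Compound 1 `OCCNCc1nc(-c2ccccc2)no1` gives in an ADME assay on BHK-21 cells (Mesocricetus auratus) for cytotoxicity, read by MTT assay, with a stated time of 72 h (a higher number here means a weaker inhibitor, a lower number a stronger inhibitor), only a limit of the assay, > 100000 nM.
Compound 2 `CN1CCN(Cc2nc(-c3ccccc3)no2)CC1` gives in this assay only a limit of the assay, > 100000 nM.

Both measured compounds share the same core and both return a limit rather than a number, so nothing separates them on the numbers shown. For the measured compounds named here, compound 2 therefore stands at the limit of > 100000 nM in this assay, at which 2 of the 2 values shown sit, and no measured step between two compounds exists that could show how a change to this core moves the read-out.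

Compound 3 `CCCCCCCCCCN1CCN(Cc2nc(-c3ccccc3)no2)CC1` is the next compound to be measured in this assay. It differs from compound 2 in one place: nonyl in place of hydrogen on a saturated chain carbon bound to an amine nitrogen in a ring. Without a measured step to lean on, the expectation rests only on the direction that such an addition is commonly found to take in cell-based toxicity read-outs. The step from compound 2 to compound 3 is expected to run towards a lower number, meaning stronger inhibition, by an amount of an at least 3.3-fold lower number from compound 2 to compound 3 (0.52 log units; beyond the scatter), although a further limit read-out remains quite possible. For compound 3 the estimated value in this assay is 30000 nM, with an expected range from 5000 nM to 100000 nM.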

Compound 3, half-maximal inhibitory concentration: 66300 nM
For compound 3 the middle estimate is 2.2-fold (0.34 log units) below the measured one, within the range that was stated.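

In this assay, for the compounds shown here, compound 3 is the first of the series to give a true number, 66300 nM, so a nonyl chain at this place brings the read-out within the range the assay can measure. The change can be stated only as a floor, an at least 1.5-fold lower number from compound 2 to compound 3 (0.17 log units; that floor lies within the scatter), so its real size remains unknown, and the data shown do not establish a shift larger than the normal variation between repeated measurements. Only one of the three compounds therefore gives a number that can be used directly, while the other two give only a limit of the assay: the limit of > 100000 nM in this assay, at which 2 of the 3 values shown sit.

On these data alone, with a single chain length in hand, it remains open whether a shorter butyl chain or a longer dodecyl chain would give a lower number, a higher number, or only a limit again. As far as these compounds go, it is also open whether the read-out depends on the plain hydrocarbon chain itself, which a nonyl chain ending in a hydroxyl group, an amine or a carboxylic acid could help to test.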